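From Chloro to Ethyl on the Shared Core

The compounds below may be only part of what the source reports. "The series", "measured", "known", "first", "only" and "open" are said of these compounds alone.

Measured compounds:
Compound 1, `Brc1ccc2ccn(CCN3CCN(C4CCCCC4)CC3)c2c1`, gives 36%.
Compound 2, `CN1CCCN(CCn2ccc3c(Br)cccc32)CC1`, gives 33%.
Compound 3, `CN1CCCN(CCn2ccc3ccc(Cl)cc32)CC1`, gives 85%.

All three were tested in an assay on HEK293 cells for binding affinity to 5-hydroxytryptamine receptor 7 (Homo sapiens), read by radioligand binding, tested at 1 uM; a lower number here means less inhibition, a higher number more inhibition at the concentration tested (going by the name of the read-out). Compound 3 stands highest of the three numbers; the nearest, compound 1, lies well beyond the usual scatter below it, and compound 2, the furthest, lies further still. Compound 3 therefore gives the highest number of the three in this assay.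

Compound 4, `CCc1ccc2ccn(CCN3CCCN(C)CC3)c2c1`, has not yet been measured. It differs from compound 3 in one place: ethyl in place of chloro on an aromatic carbon. Among the compounds with values here, nothing among the measured compounds shows what swapping chloro for ethyl does, so any expectation rests on the position alone: both groups sit on the same aromatic carbon, and both are small and uncharged.

The expected step here, a number 20 percentage points lower from compound 3 to compound 4 (beyond the scatter), is a moderate fall, because compound 3 already sits at 85% and a change at this position may cost some of that. Compound 4 is thus estimated at 65%, with a range from 35% to 90%.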

Compound 4, a percentage reported as inhibition, at one concentration (the size of the read-out at that concentration, not a potency): 66%
The estimate for compound 4 lay 1 percentage points below the measured number; measured number inside the range.
By their numbers in this assay, from the lowest: compounds 2 and 1 (each within the scatter of the next); then compound 4; then compound 3.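

Within the data shown here, putting ethyl in place of chloro on this aromatic carbon gives a number 19 percentage points lower from compound 3 to compound 4 (beyond the scatter) in this assay, the first direct reading of a change at this position. The position is therefore sensitive to which group it carries, although compound 4 still gives 66% at the concentration tested. Chloro and ethyl are alike in their counts of hydrogen-bond donors and acceptors and in having no net charge, and nothing measured here accounts for the step.

Among these compounds, with only one swap at this position, it remains open how fluoro, methoxy or a longer chain such as propyl would compare on the same carbon. Going by these compounds, it is also open whether an amine or a carboxylic acid there would be accepted at all.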